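This account rests on a few compounds, and the source may have more. Where it says the series, first, only, none or still open, it means among the compounds named here.

Three compounds have so far been run in an ADME assay on microsomes from liver (Mus musculus) for metabolic stability, read by LC-MS, with a stated time of 10 min; on this read-out higher numbers stand for a more stable compound and lower numbers for a less stable compound. Compound 1 `C[C@@H]1CN(c2cccc3c2C[C@H](CN(C)[C@H]2CCCc4cccnc42)NC3)C[C@H](C)N1` gives 85.6%, compound 2 `CN(C[C@@H]1Cc2c(cccc2N2CCNCC2)CN1)[C@H]1CCCc2cccnc21` gives 54.6%, and compound 3 `CC(C)N(C[C@H]1Cc2c(cccc2N2CCNCC2)CN1)[C@H]1CCCc2cccnc21` gives 91%. Compound 1 thus lies within the usual scatter of compound 3, and above compound 2 by a gap beyond that scatter. The next compound to be tested, compound 4 `C[C@@H]1CN(c2cccc3c2C[C@H](CN(C)[C@H]2CCCc4cccnc42)NC3)C[C@H](C)N1C`, departs from compound 1 in one place: methyl in place of hydrogen on an amine nitrogen in a ring. Going by the values given here, no two measured compounds differ in one place only, so the data offer no direct precedent for this change. A small fall in this assay is expected, perhaps none beyond the scatter, because compound 1 at 85.6% leaves little room for a rise. The expected step is a number 7.6 percentage points lower from compound 1 to compound 4 (within the scatter). For compound 4 the estimated value is 78%, with an expected range from 60% to 92%.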

Compound 4, percent of the compound remaining: 39.6%
Compound 4: the middle estimate sits 38.4 percentage points above what was measured; the measured number lies below the stated range.
By their numbers in this assay, from the lowest: compound 4; then compound 2; then compounds 1 and 3 (each within the scatter of the next).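

In this assay there is a number 46 percentage points lower from compound 1 to compound 4 (beyond the scatter) on going from 3,5-dimethylpiperazin-1-yl to 3,4,5-trimethylpiperazin-1-yl. Going by these compounds alone, this is the first comparison of compounds that differ in one place, and it shows that the read-out responds strongly at this amine nitrogen, next to two ring atoms that each bear a methyl group: one added carbon, with no hydrogen-bond donors or acceptors, is enough to carry the number beyond the scatter. Nothing measured here accounts for the fall. The compounds shown leave open whether a larger group on this nitrogen, such as ethyl or acetyl, would behave as methyl does. They also leave open whether methyl on this nitrogen would give a similar step in a piperazine without the two ring methyl groups.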